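The compounds below may be only part of what the source reports. "The series", "measured", "known", "first", "only" and "open" are said of these compounds alone.

The measured compounds in this study are:

Compound 1, `CCOC(=O)c1csc2nc(CN3CCN(C)CC3)c(-c3ccc(OC)cc3)n12`, which in a functional assay on HeLa cells (Homo sapiens) for antiproliferative activity, read by MTT assay, with a stated time of 72 h (on this read-out lower numbers stand for stronger inhibition and higher numbers for weaker inhibition), gives 35100 nM.
Compound 2, `CCOC(=O)c1csc2nc(CN3CCN(C)CC3)c(-c3ccc(Br)cc3)n12`, which in this assay gives 55400 nM.
Compound 3, `COc1ccc(-c2cnc3scc(C(=O)NNC(C)=O)n23)cc1`, which in this assay gives 17900 nM.

Compound 1 and compound 2 share one core and differ in a single place: bromo in place of methoxy on an aromatic carbon. That change made a step of a 1.6-fold higher number from compound 1 to compound 2 (0.20 log units; within the scatter). Compound 3 is built on a different core, and the difference between the two cores is not broken down here; its value lies nearest to that of compound 1 and furthest from that of compound 2.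

Compound 4, `CC(=O)NNC(=O)c1csc2ncc(-c3ccc(Br)cc3)n12`, has not yet been measured. It stands to compound 3 as compound 2 stands to compound 1: bromo in place of methoxy on an aromatic carbon. The place is described in the same words in both pairs, so this is the same change seen a second time among the four compounds.

The expectation for compound 4 rests on compound 1 and compound 2, where the change gave a 1.6-fold higher number from compound 1 to compound 2 (0.20 log units; within the scatter). A step of similar size, a 1.5-fold higher number from compound 3 to compound 4 (0.18 log units; within the scatter), is expected on the core of compound 3. Compound 4 is therefore estimated at 27000 nM in this assay, with a likely span from 12000 nM to 60000 nM.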

Compound 4, half-maximal inhibitory concentration: 4780 nM
For compound 4 the middle estimate is 5.6-fold (0.75 log units) above the measured one; the measured number lies below the stated range.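

In this assay, bromo in place of methoxy on an aromatic carbon gave a 3.7-fold lower number from compound 3 to compound 4 (0.57 log units; beyond the scatter), whereas on the core of compound 1 the same change stayed within the scatter. Going by these compounds alone, the change therefore did not carry over from one core to the other, and a step read on one core was no guide to the step on the other: the same change on two cores in this assay, a 1.6-fold higher number (0.20 log units; within the scatter) from compound 1 to compound 2 and a 3.7-fold lower number (0.57 log units; beyond the scatter) from compound 3 to compound 4, 5.9-fold (0.77 log units) apart, beyond the scatter of two such steps. This rests on a single pair for each core, and it does not show which difference between the two cores goes with the different steps, nor whether the step on the core of compound 3 would recur in further pairs.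

The compounds shown leave open whether other groups on that aromatic carbon, such as chloro, fluoro or an amine, would follow bromo or methoxy on either core. They also leave open whether the two cores would part in the same way on another cell line.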